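The source may hold more compounds than are shown below. What is called first, only, known or untested is meant among the compounds shown, and "the series" means these compounds.

Working notes on the quinolone-amide series

Compound 1 `Cc1c(C(=O)Nc2ccc(Oc3ncnc4[nH]cc(-c5ccccc5)c34)c(F)c2)c(=O)c2cc(F)ccc2n1C` and compound 2 `CCc1ccc2c(c1)c(=O)c(C(=O)Nc1ccc(Oc3ncnc4cc(OC)c(OC)cc34)c(F)c1)c(C)n2C` have been measured in an assay on isolated protein for inhibition of tyrosine-protein kinase receptor UFO (Homo sapiens), read by FRET and Z'-LYTE, with a stated time of 1.5 h; a higher number here means a weaker inhibitor, a lower number a stronger inhibitor. In this assay compound 1 gives only a limit, > 10000 nM, so no number is known for it. Compound 2 gives 4 nM in this assay; the two compounds differ in more than one place, so their gap is not read as a single step. Going by the values given here, the one point of evidence on the series is the limit of > 10000 nM in this assay, at which 1 of the 2 values shown sits.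

Compound 3 `Cc1c(C(=O)Nc2ccc(Oc3ncnc4[nH]cc(-c5ccccc5)c34)c(F)c2)c(=O)c2cc(C(C)C)ccc2n1C` is not yet measured. It differs from compound 1 in one place: isopropyl in place of fluoro on an aromatic carbon, meta to a fused ring and para to a fused ring. Among the compounds with values here, with compound 1 sitting at the limit, no measured step anchors this change; the expected step from compound 1 to compound 3 is an at least 1.1-fold lower number from compound 1 to compound 3 (0.04 log units; that floor lies within the scatter), not clearly beyond the scatter. Compound 3 is therefore expected to give about 9000 nM in this assay, within a range of 1500 nM to 40000 nM, with a fair chance that the assay again reports only a limit.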

Compound 3, half-maximal inhibitory concentration: 26 nM
Compound 3: middle estimate off by 350-fold (2.54 log units), on the high side; measured number outside the range, below it.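

In this assay, the aromatic carbon meta to a fused ring and para to a fused ring proves to be a position where a single change matters on the core of compound 1: isopropyl in place of fluoro gives an at least 380-fold lower number from compound 1 to compound 3 (2.58 log units; beyond the scatter) on this read-out. Going by these compounds alone, the earlier compounds offered no pair differing in one place, so this is the first single change that can be read. The step gives only a floor on the true size of the change, because compound 1 stands at a limit of the assay: the limit of > 10000 nM in this assay, at which 1 of the 3 values shown sits.

Fluoro and isopropyl are the only two groups shown at this position, so the response to size or shape cannot yet be described. Going by these compounds, whether an amine, a carboxylic acid or a longer chain such as n-butyl would be tolerated there remains open.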